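The source may report more compounds than this note shows. Statements on the series, on what has been measured and on what is new or still open speak of the compounds shown alone.

Working notes on the series. In an assay on CHO cells for displacement of a labelled ligand from prostaglandin E2 receptor EP3 subtype (Homo sapiens), read by radioligand binding (on this read-out lower numbers stand for stronger inhibition and higher numbers for weaker inhibition), compound 1 `CC(C)NC(=O)CC(c1ccc(-c2ccc3cccc(F)c3c2)[nH]c1=O)C(C)C` gives 5.8 nM, and compound 2 `CC(C)C(c1ccc(-c2ccc3cccc(F)c3c2)[nH]c1=O)N1CCCCC1=O` gives 6.4 nM; the step of a 1.1-fold higher number from compound 1 to compound 2 (0.04 log units; within the scatter) is within the scatter. Compound 3 `CC(C)C(/C=C1\CCNC1=O)c1ccc(-c2ccc3cccc(F)c3c2)[nH]c1=O` gives 2.2 nM in this assay, the lowest of the three numbers: the steps of a 2.6-fold lower number from compound 1 to compound 3 (0.42 log units; beyond the scatter) and a 2.9-fold lower number from compound 2 to compound 3 (0.46 log units; beyond the scatter) are both beyond the scatter, so compound 3 is the strongest binder of the set so far. Compound 4 `CC(C)C(Cc1nnn[nH]1)c1ccc(-c2ccc3cccc(F)c3c2)[nH]c1=O` is not yet measured. It differs from compound 3 at the same position as the earlier changes: a group of 6 heavy atoms (2 carbon, 4 nitrogen; one five-membered aromatic ring with 4 hetero atoms) in place of a group of 7 heavy atoms (5 carbon, 1 nitrogen, 1 oxygen; one five-membered non-aromatic ring with 1 hetero atom), on a saturated chain carbon bound to an aromatic carbon and a saturated chain carbon. Going by the values given here, no measured step involves a five-membered aromatic ring with 4 hetero atoms, so only the earlier exchanges at this position bear on it; those moved the number by the modest amounts of a 2.6-fold lower number from compound 1 to compound 3 (0.42 log units; beyond the scatter) and a 2.9-fold lower number from compound 2 to compound 3 (0.46 log units; beyond the scatter). The entering group shares nothing with the groups exchanged before, so a step in this assay at least of that size is expected, toward a higher number, with wide uncertainty: a 4.1-fold higher number from compound 3 to compound 4 (0.61 log units; beyond the scatter). For compound 4 the expected value in this assay is 9 nM, within a range from 2.5 nM to 35 nM.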

Compound 4, inhibition constant: 34 nM
Beside the measured number, compound 4's estimate is 3.8-fold (0.58 log units) below it; the measured number falls inside the stated range.
By their numbers in this assay, from the lowest: compound 3; then compounds 1 and 2 (each within the scatter of the next); then compound 4.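

Going by these compounds alone, at the position on a saturated chain carbon bound to an aromatic carbon and a saturated chain carbon, the exchanges among compounds 1, 2 and 3 moved the number only modestly or not beyond the scatter, whereas (1H-tetrazol-5-yl)methyl gives the one large step, a 15-fold higher number from compound 3 to compound 4 (1.19 log units; beyond the scatter), in this assay. Within the data shown here, the other two steps point the same way, a 5.3-fold higher number from compound 2 to compound 4 (0.73 log units; beyond the scatter) and a 5.9-fold higher number from compound 1 to compound 4 (0.77 log units; beyond the scatter), so compound 4 is the weakest binder of the four, and it is the only one whose group here holds no carbonyl. The data available offer no explanation for this loss of binding.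

Open, from the compounds shown here alone, is whether a carboxylic acid at this position would fall with compound 4 or with compounds 1, 2 and 3. Also open, going by these compounds, is whether a longer chain carrying the 1H-tetrazol-5-yl ring would change the number.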